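The source may report more compounds than this note shows. Statements on the series, on what has been measured and on what is new or still open speak of the compounds shown alone.

Measured so far in a functional assay on T98G cells (Homo sapiens) for inhibition, read by MTT assay, with a stated time of 72 h (a lower number here means a stronger inhibitor, a higher number a weaker inhibitor), follows:

- compound 1 `CC1(C)CC(NC(=O)Nc2ccc(Cl)cc2)c2cc(F)ccc2O1` gives 30000 nM
- compound 2 `CC(C)NC(=O)NC1CC(C)(C)Oc2ccc(Cl)cc21` gives > 100000 nM
- compound 3 `CC(=O)NC1CC(C)(C)Oc2ccc(Cl)cc21` gives "not determined" (no result reported)

Compound 3 has no place on this scale, since compound 3 is recorded as "not determined" (no result reported) in this assay and no number exists for it. The nearest reading is a limit. Compound 2 gives > 100000 nM as that limit of the assay. For the measured compounds named here, only compound 1 has an actual number, with compound 1 at 30000 nM as the sole firm reading.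

Compound 4 `CC1(C)CC(NC(=O)Nc2ccc(Cl)cc2)c2cc(Cl)ccc2O1` has not yet been measured. The change (4-chlorophenyl)amino in place of methyl on a carbonyl carbon puts (4-chlorophenyl)amino in place of methyl on a carbonyl carbon. Compound 1 carries the same (4-chlorophenyl)amino on its carbonyl carbon, and that compound reads 30000 nM as the closest guide available.

With no number for compound 3, the size of this step in this assay cannot be read from the data. The expectation is a step towards stronger inhibition, with a result close to that of compound 1 and still a weak one overall. A result reported only as a limit remains possible.

Compound 4 is expected at 25000 nM with an estimated range of 8000 nM to 70000 nM around that figure.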

Compound 4, half-maximal inhibitory concentration: 33000 nM
For compound 4 the middle estimate is 1.3-fold (0.12 log units) below the measured one; low and high end bracket the measured number.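

Compound 2 gives > 100000 nM in this assay, and this reading is a limit of the assay, not a number: the limit of > 100000 nM in this assay, at which 1 of the 4 values shown sits. With 4-chlorophenyl in place of isopropyl on the amide-type nitrogen, the data show an at least 3.0-fold lower number from compound 2 to compound 4 (0.48 log units; beyond the scatter), so the group at this place can move the reading by more than the usual scatter, although compound 4 is still a weak inhibitor on this scale. With chloro in place of fluoro on an aromatic carbon, the data show a 1.1-fold higher number from compound 1 to compound 4 (0.04 log units; within the scatter), which lies within the scatter, so this swap leaves no measurable mark in this assay.

From the compounds shown here alone, the step from compound 3 to compound 4 cannot be read, as compound 3 has no result, and what (4-chlorophenyl)amino does in place of methyl on the carbonyl carbon therefore remains open. Also open, going by these compounds, is how the reading would respond to a different group on the aromatic carbon, such as methoxy or nitrile, or to a carboxylic acid or an amine on the ring of the 4-chlorophenyl group.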